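This account rests on a few compounds, and the source may have more. Where it says the series, first, only, none or still open, it means among the compounds named here.

Compound 1 `Cc1ccnc(NC(c2ccc([N+](=O)[O-])cc2)c2ccc3cccnc3c2O)c1` has been tested in an assay for inhibition of protein disulfide-isomerase (Homo sapiens), with a stated time of 1 h (a higher number here means a weaker inhibitor, a lower number a stronger inhibitor), and gives 530 nM. Compound 2 `Oc1c(C(c2ccc(F)cc2)N2CCCCC2)ccc2c1OCCO2` gives 290 nM in the same assay, and its number and that of compound 1 lie within the usual scatter of each other. Compound 3 `Oc1cc2c(cc1C(c1ccc(F)cc1)N1CCCCC1)CCCC2` reaches only the assay limit, > 100000 nM, so no number is known for it (the limit of > 100000 nM in this assay, at which 1 of the 3 values shown sits). Compound 4 `Cc1ccnc(NC(c2ccc(F)cc2)c2ccc3cccnc3c2O)c1` has not yet been measured. It differs from compound 1 in one place: fluoro in place of nitro on an aromatic carbon. Among the measured compounds shown here, no measured pair shows this exchange, so its effect is open; the expectation is for a change no larger than the scatter, with the step from compound 1 to compound 4 in this assay expected as a 1.3-fold higher number from compound 1 to compound 4 (0.12 log units; within the scatter). Compound 4 is therefore estimated at 700 nM, between 250 nM and 2500 nM.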

Compound 4, half-maximal inhibitory concentration: 140 nM
The estimate for compound 4 lay 5.0-fold (0.70 log units) above the measured number, outside the stated range (below it).
By their numbers in this assay, from the lowest: compound 4; then compounds 2 and 1 (each within the scatter of the next). At a limit, above all of these: compound 3.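

Among the compounds shown here, this exchange is the first measured change at this place on the aromatic ring. In this assay going from 4-nitrophenyl to 4-fluorophenyl brings a 3.8-fold lower number from compound 1 to compound 4 (0.58 log units; beyond the scatter) and so the nitro group is not needed for inhibition in this series. The step is modest but beyond the scatter, which shows that the group at this place does shift the number.

Going by these compounds, whether a chlorine, a methoxy group or an amine here would give a lower or higher number remains open. For the compounds shown here, nothing measured so far explains why this exchange lowers the number.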